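A Carbonyl Substituent Swap from Compound 2 to Compound 3

The compounds below may be only part of what the source reports. "The series", "measured", "known", "first", "only" and "open" are said of these compounds alone.

Among the measured compounds shown here, compound 2 `COc1cc(Cl)cc(-c2nn(-c3cccc(NC(=O)Nc4cccc(C(F)(F)F)c4)c3)cc2-c2ccncc2)c1` gives 55% in a functional assay on MOLT-4 cells (Homo sapiens) for inhibition, read by sulforhodamine B assay, with a stated time of 48 h, tested at 1 uM (on this read-out higher numbers stand for a weaker effect at the one concentration tested and lower numbers for a stronger effect), the lowest of the two numbers measured so far, while compound 1 `COc1cc(Cl)cc(-c2nn(-c3cccc(NC(=O)Nc4ccc(Cl)c(Cl)c4)c3)cc2-c2ccncc2)c1` gives 70%. For the measured compounds named here, the only measured step, a number 15 percentage points lower from compound 1 to compound 2 (beyond the scatter), changes the group on the amide-type nitrogen and does not touch the carbonyl carbon. Compound 3 `COc1cc(Cl)cc(-c2nn(-c3cccc(NC(=O)c4cccc(C(F)(F)F)c4)c3)cc2-c2ccncc2)c1` differs from compound 2 by 3-(trifluoromethyl)phenyl in place of (3-(trifluoromethyl)phenyl)amino on a carbonyl carbon. Going by the values given here, no measured step bears on this change, so its direction rests on no precedent here. A modest weakening is nonetheless expected, a number 10 percentage points higher from compound 2 to compound 3 (within the scatter). Compound 3 is estimated at 65%, within 45% to 85%.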

Compound 3, a percentage reported as activity, at one concentration (the size of the read-out at that concentration, not a potency): 72%
Beside the measured number, compound 3's estimate is 7 percentage points below it, and the stated range covers the measured number.
By their numbers in this assay, from the lowest: compound 2; then compounds 1 and 3 (each within the scatter of the next).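

Among the compounds shown here, this is the first measured change on the carbonyl carbon, and in this assay it gives a number 17 percentage points higher from compound 2 to compound 3 (beyond the scatter), so 3-(trifluoromethyl)phenyl does not keep the effect of (3-(trifluoromethyl)phenyl)amino at this place. The other new step, a number 2 percentage points higher from compound 1 to compound 3 (within the scatter), lies within the scatter, so compound 3 does not retain the advantage that compound 2 holds over compound 1. Nothing measured here explains the step. The compounds shown leave open whether a methylene or an oxygen linking the ring to the carbonyl carbon would behave like the amino group. They also leave open how 3,4-dichlorophenyl itself would behave on the carbonyl carbon.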